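The compounds below may be only part of what the source reports. "The series", "measured", "known", "first", "only" and "open" are said of these compounds alone.

Of the compounds shown here, two have so far been measured in a functional assay on NCI-H460 cells (Homo sapiens) for cytotoxicity, read by MTT assay, with a stated time of 72 h; a higher number here means a weaker inhibitor, a lower number a stronger inhibitor. Compound 1 `CCNC1=CC(=O)C=C(C(C)(C)C)C1=O` gives 13000 nM. Compound 2 `CCCCCCCCNC1=CC(=O)C(C(C)(C)C)=CC1=O` gives 70000 nM, the higher of the two numbers, and the gap between compound 2 and compound 1 lies beyond the usual scatter of repeated measurements, so compound 2 is the weaker inhibitor of the pair. The two differ in more than one place, so no single step can be read between them.

Compound 3 `CCCCNC1=CC(=O)C(C(C)(C)C)=CC1=O` has not yet been measured. It keeps the core of compound 2 and differs from it in one place only: hydrogen in place of butyl on a saturated chain carbon, four bonds along the chain from an amine nitrogen. Among the compounds with values here, no measured pair shows this exact change, so the size of the step can only be estimated. Within the data shown here, the one hint is that compound 1, which carries an ethyl on the amine nitrogen, also has the lower number, at 13000 nM. On that slim basis the expected step of a 2.0-fold lower number from compound 2 to compound 3 (0.30 log units; within the scatter) is towards a lower number, modest in size and close to the edge of the scatter. Compound 3 is therefore estimated at 35000 nM, with a likely range from 12000 nM to 100000 nM.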

Compound 3, half-maximal inhibitory concentration: 36000 nM
Compound 3: middle estimate off by 1.0-fold (0.01 log units), on the low side, within the range that was stated.
By their numbers in this assay, from the lowest: compound 1; then compounds 3 and 2 (each within the scatter of the next).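

In this assay, within the data shown here, the exchange of hydrogen for butyl on a saturated chain carbon, four bonds along the chain from an amine nitrogen, gives a 1.9-fold lower number from compound 2 to compound 3 (0.29 log units; within the scatter) and is the first step that can be read at this place. Four carbon atoms leave the chain in this step, yet compound 2 and compound 3 cannot be told apart in this assay, so on this one pair the outer part of the chain makes no readable difference to the number. Nothing measured here bears on why the outer part of the chain counts for so little.

A single pair cannot show whether the same holds further along the chain, for example with a propyl, an ethyl or a methyl on the amine nitrogen of this same core, or with a chain longer than that of compound 2. It also leaves open what a chain ending in a carboxylic acid or an amine, or a ring such as cyclohexyl at this place, would do to the number.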